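The source may report more compounds than this note shows. Statements on the series, on what has been measured and on what is new or still open speak of the compounds shown alone.

Compound 1, `O=C(CSc1nc2c(c(=O)n1-c1ccc(F)cc1)SCC2)Nc1nc2ccc(C(F)(F)F)cc2s1`, and compound 2, `Cc1ccc2nc(NC(=O)CSc3nc4c(c(=O)n3-c3ccc(F)cc3)SCC4)sc2c1`, share one core and are told apart by a single substituent on the fused ring system. In an assay on L cells for inhibition of Protein-serine O-palmitoleoyltransferase porcupine (Mus musculus), read by reporter gene assay, with a stated time of 24 h (on this read-out lower numbers stand for an effect already at smaller amounts and higher numbers for an effect only at larger amounts of compound), compound 1 gives 100 nM, and compound 2 gives 40 nM. The change between them is methyl in place of trifluoromethyl on an aromatic carbon and it produced a 2.5-fold lower number from compound 1 to compound 2 (0.40 log units; beyond the scatter).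

Compound 3, `O=C(CNC(=O)c1nn(-c2ccc(F)cc2)c(=O)c2ccccc12)Nc1nc2ccc(C(F)(F)F)cc2s1`, carries the same trifluoromethyl-bearing fused ring system as compound 1 but on a different core; the difference between the two cores is not broken down here. In this assay compound 3 gives 90 nM, which lies within the scatter of the value of compound 1.

Compound 4, `Cc1ccc2nc(NC(=O)CNC(=O)c3nn(-c4ccc(F)cc4)c(=O)c4ccccc34)sc2c1`, has not yet been measured. It stands to compound 3 as compound 2 stands to compound 1: the change is methyl in place of trifluoromethyl on an aromatic carbon. Since the place of the change is described in the same words for both pairs, this is the same change made on a second core.

Within the data shown here, the expectation for compound 4 rests on the single precedent, the step from compound 1 to compound 2 in this assay, because a 2.5-fold lower number from compound 1 to compound 2 (0.40 log units; beyond the scatter) was observed there and compound 3 sits within the scatter of compound 1 as a starting point. Compound 4 is therefore expected to show a 2.3-fold lower number from compound 3 to compound 4 (0.35 log units; beyond the scatter). The estimate for compound 4 in this assay is 40 nM, with a range from 20 nM to 90 nM, the wider range reflecting that one precedent on a different core is a thin basis.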

Compound 4, half-maximal effective concentration: 100 nM
Compound 4: the middle estimate sits 2.5-fold (0.40 log units) below what was measured, and the stated range ends below it.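

In this assay, methyl in place of trifluoromethyl on an aromatic carbon gave a 1.1-fold higher number from compound 3 to compound 4 (0.05 log units; within the scatter), so the change that moved the number on the core of compound 1 left no readable mark on the core of compound 3. Set side by side, the two steps do not agree, which shows that in this series the result of this change did not carry over from one core to the other: the same change on two cores in this assay, a 2.5-fold lower number (0.40 log units; beyond the scatter) from compound 1 to compound 2 and a 1.1-fold higher number (0.05 log units; within the scatter) from compound 3 to compound 4, 2.8-fold (0.44 log units) apart, beyond the scatter of two such steps. Among these compounds, this rests on only two pairs, however, and the two cores differ in more than one place, so the four compounds do not tell which part of the cores accounts for the gap, nor what the same change would do on a third core.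

All four compounds carry either trifluoromethyl or methyl at this place, which leaves open how other groups there, such as a chlorine atom, a methoxy group or a nitrile, would read on either core. As far as these compounds go, it also remains open whether such groups would show the same split between the two cores or would behave alike on both.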